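A few compounds are considered here, and "the series" means these few. Any claim that something is new, unique, unknown or untested is made for them only; others in the source may bear on it.

Measured compounds: compound 1 `O=S(=O)(c1ccccc1)c1nc2ccccc2nc1Nc1ccccc1` with 590 nM, compound 2 `O=S(=O)(c1ccccc1)c1nc2ccccc2nc1Nc1ccc(F)cc1` with 14200 nM, and compound 3 `O=S(=O)(c1ccccc1)c1nc2ccccc2nc1Nc1ccc(Cl)cc1` with 15300 nM, all in a functional assay on PC-3 cells (Homo sapiens) for cytotoxicity, read by MTT assay, with a stated time of 72 h; a higher number here means a weaker inhibitor, a lower number a stronger inhibitor.

Compound 1 gives the lowest number of the three. Compound 4 `COc1ccc(S(=O)(=O)c2nc3ccccc3nc2Nc2ccccc2)cc1` differs from it by methoxy in place of hydrogen on an aromatic carbon. Going by the values given here, no measured step covers this change; the steps that exist, a 24-fold higher number from compound 1 to compound 2 (1.38 log units; beyond the scatter) and a 26-fold higher number from compound 1 to compound 3 (1.41 log units; beyond the scatter), both concern a halogen entering a ring of compound 1, and both were large weakenings, whereas a 1.1-fold higher number from compound 2 to compound 3 (0.03 log units; within the scatter) stayed within the scatter. They bear only loosely on a methoxy entering elsewhere, and the direction is uncertain. Compound 4 is therefore expected to give about 1500 nM, within 400 nM to 6000 nM, as a step of a 2.5-fold higher number from compound 1 to compound 4 (0.41 log units; beyond the scatter).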

Compound 4, half-maximal inhibitory concentration: 1260 nM
Estimate against measurement, compound 4: 1.2-fold (0.08 log units) above, within the range that was stated.
By their numbers in this assay, from the lowest: compound 1; then compound 4; then compounds 2 and 3 (each within the scatter of the next).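

In this assay, the change from phenyl to 4-methoxyphenyl brings only a modest weakening (a 2.1-fold higher number from compound 1 to compound 4 (0.33 log units; beyond the scatter)), whereas a halogen entering the other phenyl ring of compound 1 brought a large one (a 24-fold higher number from compound 1 to compound 2 (1.38 log units; beyond the scatter)). The methoxy step is thus the first to show that compound 1 can carry a substituent with a far smaller loss, though compound 1 still gives the lowest number. Nothing measured here accounts for this difference. From the compounds shown here alone, whether an ethoxy group, a hydroxyl or an amine at this place would behave like methoxy remains open. So does the effect of methoxy on the other phenyl ring.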